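A ring exchange on the chain of compound 2

The source may hold more compounds than are shown below. What is called first, only, known or untested is meant among the compounds shown, and "the series" means these compounds.

Compound 1 (`CC(C)C(CC1C(=O)NC(=O)N1C)c1ccc(-c2ccc3cccc(F)c3c2)[nH]c1=O`) gives 0.153 h
Compound 2 (`CC(C)[C@@H](c1ccc(-c2ccc3cccc(F)c3c2)[nH]c1=O)[C@@H]1OC(=O)NC1=O`) gives > 3 h (a limit)
Compound 3 (`O=C1NC(=O)/C(=C/C2(c3ccc(-c4ccc5cccc(F)c5c4)[nH]c3=O)CCCC2)O1`) gives > 3 h (a limit)

All of these readings come from an ADME assay on microsomes from liver (Homo sapiens) for metabolic stability; on this read-out higher numbers stand for a longer-lived compound and lower numbers for a shorter-lived compound. For compound 2 the reading (> 3 h) is a limit and not a number. Its place among the three is given by the limit of > 3 h in this assay, at which 2 of the 3 values shown sit. Only compound 1 has a number rather than a limit.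

Compound 4 (`CC(C)[C@H](C[C@H]1SC(=O)NC1=O)c1ccc(-c2ccc3cccc(F)c3c2)[nH]c1=O`) has not yet been measured. It carries (2,4-dioxo-1,3-thiazolidin-5-yl)methyl in place of 2,4-dioxo-1,3-oxazolidin-5-yl on a saturated chain carbon bound to an aromatic carbon and a saturated chain carbon.

Among the compounds with values here, no two measured compounds differ in one place only, so any expectation has to lean on a looser comparison. Compound 1 (0.153 h) also holds a five-membered non-aromatic ring through a methyl link, as compound 4 does and compound 2 does not. On that single comparison, a shorter half-life is expected, beyond the usual scatter, with an estimated step of an at least 3.7-fold lower number from compound 2 to compound 4 (0.57 log units; beyond the scatter). The ring in compound 1 is not the one that enters here, so the expectation stays wide. For compound 4 the estimate is 0.8 h, with an expected range from 0.2 h to 3 h.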

Compound 4, half-life: 0.67 h
Compound 4: the middle estimate sits 1.2-fold (0.08 log units) above what was measured, and the stated range covers the measured number.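

In this assay the exchange on a saturated chain carbon bound to an aromatic carbon and a saturated chain carbon gives an at least 4.4-fold lower number from compound 2 to compound 4 (0.65 log units; beyond the scatter), which shows that the half-life answers to the group carried at this position even when a five-membered non-aromatic ring with 2 hetero atoms is kept. The reading for compound 2 is a limit and not a number, so the true size of this step stays unknown: the limit of > 3 h in this assay, at which 2 of the 4 values shown sit.

The two groups match in hydrogen-bond donors, hydrogen-bond acceptors and net charge, yet the change is a double one, since sulfur takes the place of a ring oxygen and a methyl link is added to the chain.

The compounds shown leave open whether the step follows the sulfur or the methyl link, a question that 2,4-dioxo-1,3-thiazolidin-5-yl set directly on this carbon would address. Also open, as far as these compounds go, is how a group without such a ring, such as a carboxylic acid or an amine on the same carbon, would behave in this assay.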